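Swapping the Bromomethyl Group for a Nitrooxyethyl Chain

A few compounds are considered here, and "the series" means these few. Any claim that something is new, unique, unknown or untested is made for them only; others in the source may bear on it.

Compound 1 `COc1ccc(C2=NN(C(=O)CBr)C(c3ccco3)C2)cc1OC` and compound 2 `COc1ccc(C2=NN(C(=O)CBr)C(c3c(Cl)cccc3Cl)C2)cc1OC` share one core and were both tested in a functional assay on the whole organism (strain albino) for inhibition, with Rattus norvegicus as the target, read by paw edema, with stated times of 30 min and 3 h, at a dose of 100 mg/kg by the oral route; on this read-out higher numbers stand for more inhibition at the one dose given (going by the name of the read-out) and lower numbers for less inhibition. Compound 1 gives 51%, and compound 2 gives 69%. The step of a number 18 percentage points higher from compound 1 to compound 2 (beyond the scatter) accompanies a swap of the group on a saturated ring carbon. Compound 1 thus stands lowest of the two numbers shown, with compound 2 as its only neighbour. Compound 3 `COc1ccc(C2=NN(C(=O)C(C)O[N+](=O)[O-])C(c3ccco3)C2)cc1OC` differs from compound 1 elsewhere: 1-(nitrooxy)ethyl in place of bromomethyl on a carbonyl carbon. Among the measured compounds shown here, the only measured step, from compound 1 to compound 2, touches a different part of the molecule, so no measured pair shows what exchanging a bromomethyl for a 1-(nitrooxy)ethyl on the carbonyl carbon does in this assay. Without such guidance, no step beyond the scatter is expected in either direction, and the estimated change is no change at the digits printed from compound 1 to compound 3 (within the scatter). Compound 3 is therefore expected to give 51%, within a range of 33% to 70%.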

Compound 3, a percentage reported as inhibition, in the whole organism at one dose (the size of the read-out at that dose, not a potency): 42%
The estimate for compound 3 lay 9 percentage points above the measured number, within the range that was stated.
By their numbers in this assay, from the lowest: compounds 3 and 1 (each within the scatter of the next); then compound 2.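

The exchange of bromomethyl for 1-(nitrooxy)ethyl on the carbonyl carbon gives a number 9 percentage points lower from compound 1 to compound 3 (within the scatter) in this assay. Among the compounds shown here, this is the first measured change at this position, and it shows that with furan-2-yl kept on the shared core, the larger 1-(nitrooxy)ethyl group of 6 heavy atoms can replace the bromomethyl group of 2 without moving the number beyond the usual scatter. No supporting measurement is available to explain this result.

Still open, as far as these compounds go, is whether the same exchange would hold up on compound 2, which carries 2,6-dichlorophenyl in place of furan-2-yl. From the compounds shown here alone, it is also open how a plain ethyl group, an amine or a longer chain ending in nitrooxy would behave on the same carbonyl carbon, which would help separate the effect of the nitrooxy group from that of losing the bromine.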